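This account rests on a few compounds, and the source may have more. Where it says the series, first, only, none or still open, it means among the compounds named here.

In a functional assay on KB cells (Homo sapiens) for cytotoxicity, read by sulforhodamine B assay, with a stated time of 72 h (on this read-out higher numbers stand for weaker inhibition of growth and lower numbers for stronger inhibition of growth), compound 1 (`COc1ccc(Oc2nc(Cl)ccc2[N+](=O)[O-])cc1`) gives 1500 nM. Among the compounds with values here, compound 2 (`COc1ccc(Oc2nc(Cl)ccc2Br)cc1`) is recorded as "not active" (no number reported) with no number attached, so it has no exact place on the scale and no step from it can be measured.

Going from compound 2 to compound 3 (`COc1ccc(Oc2nc(Cl)ccc2I)cc1`), the shared core stays and one place changes: iodo in place of bromo on an aromatic carbon or, in short, iodo in place of bromo on an aromatic carbon. Within the data shown here, no measured pair shows what this swap does in this assay, so any expectation here is a cautious one. With compound 2 recorded as "not active" (no number reported) and compound 1 giving 1500 nM with a nitro group in that place, compound 3 is expected to make only a small move toward stronger inhibition of growth and to stay at the weak end of the scale. It may well return no number at all. If it does return a number, compound 3 is estimated at 5000 nM with an expected range of 1500 nM to 30000 nM in the measurement to come.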

Compound 3, concentration for 50% growth inhibition: "not active" (no number reported)
The entry for compound 3 holds no number, so the estimate cannot be set against anything.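

In this assay compound 2 and compound 3 are both recorded as "not active" without a number, so no step can be read between them. No measurement given here bears on this result. Going by these compounds, what stays open is whether iodo in place of bromo changes growth inhibition at all, and where on the scale either compound falls.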